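The compounds below may be only part of what the source reports. "The series", "measured", "known", "first", "only" and "open" are said of these compounds alone.

Three compounds share one core and differ only in the group on a saturated chain carbon bound to a nitrogen on an aromatic ring. In a functional assay on HL-60 cells (Homo sapiens) for antiproliferative activity, with a stated time of 72 h (a lower number here means a stronger inhibitor, a higher number a weaker inhibitor), compound 1 `OC[C@H]1O[C@@H](n2cnc3c(NCc4ccccc4Cl)ncnc32)[C@H](O)[C@@H]1O` gives 1600 nM, compound 2 `OC[C@H]1O[C@@H](n2cnc3c(NCc4ccc(Cl)cc4)ncnc32)[C@H](O)[C@@H]1O` gives 1700 nM, and compound 3 `OC[C@H]1O[C@@H](n2cnc3c(NCc4ccc(Cl)c(Cl)c4)ncnc32)[C@H](O)[C@@H]1O` gives 2000 nM. Compound 2 sits between the other two on these numbers, yet all three lie within the scatter of one another. Compound 4 `COc1cccc(CNc2ncnc3c2ncn3[C@@H]2O[C@H](CO)[C@@H](O)[C@H]2O)c1OC` carries 2,3-dimethoxyphenyl in place of 4-chlorophenyl on a saturated chain carbon bound to a nitrogen on an aromatic ring. Among the measured compounds shown here, the steps that bear on this change, a 1.1-fold higher number from compound 1 to compound 2 (0.03 log units; within the scatter) and a 1.3-fold higher number from compound 1 to compound 3 (0.10 log units; within the scatter), each swap one chlorinated ring for another and stay within the scatter; no swap to a methoxy-bearing ring has been measured. The expected step is therefore a 1.2-fold higher number from compound 2 to compound 4 (0.07 log units; within the scatter), nothing beyond the scatter. Compound 4 is estimated at 2000 nM, with a range from 700 nM to 6000 nM.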

Compound 4, half-maximal inhibitory concentration: > 166000 nM
Compound 4 gave a limit, no number (the forecaster's own chance of this, stated with the estimate: 5%); middle value at least 83-fold (1.91 log units) away from the limit.
By their numbers in this assay, from the lowest: compounds 1, 2 and 3 (each within the scatter of the next). At a limit, above all of these: compound 4.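

The three chlorinated rings stay within the scatter of one another, so they gave no sign that this position could matter much. The change to 2,3-dimethoxyphenyl shows that it can in this assay, with an at least 97-fold higher number from compound 2 to compound 4 (1.98 log units; beyond the scatter), an at least 83-fold higher number from compound 3 to compound 4 (1.91 log units; beyond the scatter) and an at least 100-fold higher number from compound 1 to compound 4 (2.01 log units; beyond the scatter). Compound 4 gives a limit, not a number: the limit of > 166000 nM in this assay, at which 1 of the 4 values shown sits.

As far as these compounds go, whether one methoxy group is enough for such a step, or both are needed, stays open. How a ring carrying a hydroxyl or an amine would read at this position is open too.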